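This account rests on a few compounds, and the source may have more. Where it says the series, first, only, none or still open, it means among the compounds named here.

Compound 1 `CCO/C(O)=C1\C(C)=NC(C)=C([N+](=O)[O-])C1c1ccncc1`: 6460 nM. Compound 2 `CC1=NC(C)=C([N+](=O)[O-])C(c2cccnc2)/C1=C(\O)OC1CCCCC1`: 2760 nM.

In a functional assay (cardiac atrium) for agonist activity, with Cavia porcellus as the target (on this read-out lower numbers stand for an effect already at smaller amounts and higher numbers for an effect only at larger amounts of compound), compound 1 gives 6460 nM, the higher of the two numbers shown, while compound 2 gives 2760 nM, a lower number, and that gap lies beyond the usual scatter. Going by the values given here, no measured pair differs in only one place, so no counted step is available. Compound 3 `CCO/C(O)=C1\C(C)=NC(C)=C([N+](=O)[O-])C1c1ccccn1` is still to be measured in this assay. It differs from compound 1 as follows: pyridin-2-yl in place of pyridin-4-yl on a saturated ring carbon. Without a comparable step on record, a modest move toward a higher number is expected, of about a 1.5-fold higher number from compound 1 to compound 3 (0.19 log units; within the scatter). Compound 3 is therefore estimated at 10000 nM, within 3000 nM to 30000 nM.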

Compound 3, half-maximal effective concentration: 22800 nM
Compound 3: middle estimate off by 2.3-fold (0.36 log units), on the low side, within the range that was stated.
By their numbers in this assay, from the lowest: compound 2; then compound 1; then compound 3.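

In this assay, the step from pyridin-4-yl to pyridin-2-yl on the saturated ring carbon gives a 3.5-fold higher number from compound 1 to compound 3 (0.55 log units; beyond the scatter). The two groups have the same atoms and the same counts, so where the pyridine is joined alone separates these compounds on this read-out. Nothing on record explains this shift.

Open, from the compounds shown here alone, is how pyridin-3-yl would read on the core of compound 1, as compound 2 carries that group together with cyclohexyl in place of ethyl. Also open, going by these compounds, is how a phenyl group on this carbon would compare with either pyridine.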